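The compounds below may be only part of what the source reports. "The series", "measured", "known", "first", "only" and "open" are said of these compounds alone.

Measured so far:
compound 2 `Cc1ccc(-n2nc(C(=O)Nc3ccc(Oc4ncnc5ccsc45)cc3)c(C)cc2=O)cc1` — 23800 nM
compound 1 `Cc1cc(=O)n(-c2ccc(Br)cc2F)nc1C(=O)Nc1ccc(Oc2ncnc3ccsc23)cc1` — 9360 nM

In a functional assay on MCF7 cells (Homo sapiens) for cytotoxicity, read by MTT assay, with a stated time of 72 h (on this read-out lower numbers stand for stronger inhibition and higher numbers for weaker inhibition), compound 2 gives 23800 nM, the highest of the two numbers. For the measured compounds named here, its nearest neighbour, compound 1, gives 9360 nM; the single measured step, a 2.5-fold higher number from compound 1 to compound 2 (0.41 log units; beyond the scatter), lies beyond the scatter and is modest in size.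

Compound 3 `Cc1ccc(-n2nc(C(=O)Nc3ccc(Oc4ncnc5ccsc45)c(F)c3)c(C)cc2=O)cc1` is the next member. It differs from compound 2 by fluoro in place of hydrogen on an aromatic carbon. Going by the values given here, no measured step bears on this change: the only step in hand exchanges the aryl group on the aromatic nitrogen, a different part of the shared core, and says nothing about a substituent on the ring carrying the amide. The change itself is small, a single fluorine entering.

With nothing to point either way, the expected step is within the scatter: a 1.2-fold lower number from compound 2 to compound 3 (0.08 log units; within the scatter). The estimate for compound 3 in this assay is 20000 nM, with a range of 7000 nM to 60000 nM.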

Compound 3, half-maximal inhibitory concentration: 7250 nM
The estimate for compound 3 lay 2.8-fold (0.44 log units) above the measured number; the range from low to high includes it.
By their numbers in this assay, from the lowest: compounds 3 and 1 (each within the scatter of the next); then compound 2.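

In this assay, the ring carrying the amide proves to be a position that responds: fluoro in place of hydrogen, ortho to a large group and meta to a large group, gives a 3.3-fold lower number from compound 2 to compound 3 (0.52 log units; beyond the scatter). For the compounds shown here, the only earlier step, a 2.5-fold higher number from compound 1 to compound 2 (0.41 log units; beyond the scatter), exchanged the aryl group on the aromatic nitrogen, so the series now has a measured change beyond the scatter at a second place on the shared core. No available evidence accounts for the effect of this single fluorine.

From the compounds shown here alone, it remains open whether chloro, methoxy or an amine on the same aromatic carbon would move the number in the same direction. Going by these compounds, it is also open whether the fluoro step carries over when 4-bromo-2-fluorophenyl replaces 4-methylphenyl on the aromatic nitrogen.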